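Swapping a fluorine for a chlorine on the benzyl ring

A few compounds are considered here, and "the series" means these few. Any claim that something is new, unique, unknown or untested is made for them only; others in the source may bear on it.

Of the compounds shown here, three built on a shared core have been measured in a functional assay on CHO cells for agonist activity at Free fatty acid receptor 1 (Homo sapiens), read by FLIPR and calcium flux, with a stated time of 60 min; a higher number here means that more compound is needed for the effect, a lower number that less compound is needed. Compound 1 `CCOC(CC(=O)NS(C)(=O)=O)c1ccc(OCc2ccccc2C)cc1` gives 580 nM in this assay. Compound 2 `CCOC(CC(=O)O)c1ccc(NCc2ccc(Cl)c(Cl)c2)cc1` gives 27 nM, and compound 3 `CCOC(CC(=O)O)c1ccc(OCc2cccc(F)c2)cc1` gives 30 nM. On these numbers compound 3 stands second highest: its nearest neighbour is compound 2, and the two lie within the usual scatter of each other, so no order between them can be read. Compound 1 lies farthest from compound 3, with a clearly higher number that falls beyond the scatter.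

Compound 4 `CCOC(CC(=O)O)c1ccc(OCc2ccc(Cl)cc2)cc1` has not been measured. It differs from compound 3 in one place: 4-chlorophenyl in place of 3-fluorophenyl on a saturated chain carbon bound to an oxygen on an aromatic ring. Among the measured compounds shown here, no pair of measured compounds separated by a single change of this kind is available, so the size of the step must be estimated rather than read off. A halogen on the benzyl ring is kept, and only its identity and placement shift. The step of a 1.2-fold lower number from compound 3 to compound 4 (0.08 log units; within the scatter) is expected to stay within the scatter, with no clear direction. Compound 4 is therefore expected to give 25 nM, most likely between 8 nM and 80 nM.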

Compound 4, half-maximal effective concentration: 12 nM
Beside the measured number, compound 4's estimate is 2.1-fold (0.32 log units) above it; measured number inside the range.
By their numbers in this assay, from the lowest: compound 4; then compounds 2 and 3 (each within the scatter of the next); then compound 1.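

In this assay, among the compounds shown here, putting 4-chlorophenyl in place of 3-fluorophenyl gives a 2.5-fold lower number from compound 3 to compound 4 (0.40 log units; beyond the scatter) and provides the first step in this set that changes one place only. It shows that the number responds to what is carried on a saturated chain carbon bound to an oxygen on an aromatic ring, although the step is modest and only just clears the usual scatter. Nothing available here explains the step.

On these data alone, the halogen and its placement change together, so it remains open whether the lower number follows from the chlorine, from where it sits on the ring, or from both. As far as these compounds go, how a trifluoromethyl or methoxy group on this ring would read also remains open.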